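The compounds below may be only part of what the source reports. "The series", "measured", "known", "first", "only" and "open" are said of these compounds alone.

This account follows one change on a shared core. Compound 1, `CCCn1ncnc1-c1ccccc1NCC1=NCCN1`, gives 316 nM in an in vitro functional assay on cells (Fibroblast) for agonist activity at Alpha-1B adrenergic receptor (Homo sapiens); on this read-out higher numbers stand for an effect only at larger amounts of compound and lower numbers for an effect already at smaller amounts. Compound 2, `Cn1nccc1-c1ccccc1NCC1=NCCN1`, is known in this assay only as a limit of < 100000 nM rather than a number, and so compound 2 stands on the limit of < 100000 nM in this assay, at which 1 of the 2 values shown sits, without a firm place among the values shown. Compound 3, `CC(C)n1nccc1-c1ccccc1NCC1=NCCN1`, differs from compound 2 by isopropyl in place of methyl on an aromatic nitrogen. Among the compounds with values here, no measured pair of compounds shows this change, so its size is not known from the data. Compound 3 is expected to reach an effect at smaller amounts than the limit for compound 2 allows, a step that the limit leaves unreadable from compound 2 to compound 3 in this assay, though the direction and size remain uncertain. Compound 3 is estimated at 3000 nM, with a range from 300 nM to 30000 nM.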

Compound 3, half-maximal effective concentration: < 100000 nM
Compound 3: a limit, no number; the forecaster's own chance of this, stated with the estimate: 30%; the middle value is on the limit's open side.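

Like compound 2, compound 3 is known in this assay only as a limit, < 100000 nM. Within the data shown here, no step between compound 2 and compound 3 can be read. The compounds shown leave open whether isopropyl in place of methyl on an aromatic nitrogen changes the amount of compound needed for an effect, and by how much.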